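Chlorophenyl swap: from compound 3 to compound 4

A few compounds are considered here, and "the series" means these few. Any claim that something is new, unique, unknown or untested is made for them only; others in the source may bear on it.

Measured so far in an ADME assay on microsomes from liver (Rattus norvegicus, strain Sprague-Dawley) for metabolic stability, read by LC-MS, with a stated time of 15 min, tested at 20 uM; on this read-out higher numbers stand for a more stable compound and lower numbers for a less stable compound:
compound 1 `COc1ccc(CNC(=O)c2c(C)nc3cc(C)ccn23)cc1` gives 33.6%
compound 2 `COc1ccccc1CNC(=O)c1c(C)nc2cc(C)ccn12` gives 41.6%
compound 3 `Cc1ccn2c(C(=O)NCc3ccccc3Cl)c(C)nc2c1` gives 58.9%

Compound 3 holds the highest number of the three, and its gaps to compound 1 and compound 2 both lie beyond the scatter. The next compound to be read is compound 4 `Cc1ccn2c(C(=O)NCc3ccc(Cl)cc3)c(C)nc2c1`, which carries 4-chlorophenyl in place of 2-chlorophenyl on a saturated chain carbon bound to an amide-type nitrogen. The two have the same atoms, joined differently.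

Within the data shown here, only one measured step exists, the modest a number 17.3 percentage points higher from compound 2 to compound 3 (beyond the scatter), and it exchanges methoxy for chloro rather than moving a group, so it bears only indirectly on this change. The nearer guide is the methoxy pair, which differs in where that group sits: compound 1 at 33.6% and compound 2 at 41.6% lie within the scatter of each other. This is a single pair, and the data hold no measured case of moving chloro. No step beyond the scatter is therefore expected in this assay, though a small fall is the likelier direction. The estimated change is a number 6.9 percentage points lower from compound 3 to compound 4 (within the scatter). The expected value for compound 4 is 52%, with an estimated range of 38% to 66%.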

Compound 4, percent of the compound remaining in the Rattus norvegicus assay: 80.7%
Compound 4: middle estimate off by 28.7 percentage points, on the low side, outside the stated range (above it).
By their numbers in the Rattus norvegicus assay, from the lowest: compounds 1 and 2 (each within the scatter of the next); then compound 3; then compound 4.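

In the Rattus norvegicus assay, 4-chlorophenyl in place of 2-chlorophenyl on a saturated chain carbon bound to an amide-type nitrogen gives a number 21.8 percentage points higher from compound 3 to compound 4 (beyond the scatter), so where chloro sits on the phenyl ring counts on this read-out, whereas the two methoxy compounds, compound 1 at 33.6% and compound 2 at 41.6%, lie within the scatter of each other. Among these compounds, in the Rattus norvegicus assay chloro in place of methoxy now has a second reading, a number 47.1 percentage points higher from compound 1 to compound 4 (beyond the scatter), and the size of this exchange differs with where the group sits: the same change on two cores in the Rattus norvegicus assay, a number 17.3 percentage points higher (beyond the scatter) from compound 2 to compound 3 and a number 47.1 percentage points higher (beyond the scatter) from compound 1 to compound 4, 29.8 percentage points apart, beyond the scatter of two such steps In a physicochemical assay for metabolic stability, read by LC-MS, in simulated gastric fluid, with a stated time of 15 min, tested at 50 uM (on this read-out higher numbers stand for a more stable compound and lower numbers for a less stable compound), the same move between the chlorophenyl groups gives a number 2.9 percentage points lower from compound 3 to compound 4 (within the scatter), with compound 3 at 97.2% and compound 4 at 94.3%, so the gain has no counterpart in the physicochemical assay.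

On these data alone, whether the gain belongs to chloro itself stays open; a bromo or trifluoromethyl group in place of chloro on the 4-chlorophenyl ring would test that. Also open, as far as these compounds go, is whether the step from 2-chlorophenyl to 4-chlorophenyl holds on any core other than the shared one.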